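Adding Fluorine Where Every Measured Neighbour Sits at the Limit

This account rests on a few compounds, and the source may have more. Where it says the series, first, only, none or still open, it means among the compounds named here.

Compound 1 `CN(Cc1cccc(F)c1)C(=O)CN(C)C(=O)c1ccc(S(C)(=O)=O)c([N+](=O)[O-])c1` gives > 60000 nM in an assay on isolated protein for inhibition of thyroid hormone receptor alpha (Homo sapiens), read by fluorescence polarization; a higher number here means a weaker inhibitor, a lower number a stronger inhibitor; this is a limit of the assay, not a number.
Compound 2 `CN(Cc1ccccc1F)C(=O)CNC(=O)c1ccc(S(C)(=O)=O)c([N+](=O)[O-])c1` gives > 60000 nM in this assay; this too is a limit, not a number.
Compound 3 `CN(Cc1ccccc1)C(=O)CNC(=O)c1ccc(S(C)(=O)=O)c([N+](=O)[O-])c1` gives > 60000 nM in this assay; again a limit, not a number.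

Compound 3 therefore stands at the limit of this assay, and so do the two other measured compounds, so no ordering among the three can be read from these values. Going by the values given here, the only step between measured compounds that differ in a single place, a step that the two limits leave unreadable from compound 2 to compound 3, has no readable size because of the limit of > 60000 nM in this assay, at which 3 of the 3 values shown sit.

Compound 4 `CN(Cc1cccc(F)c1)C(=O)CNC(=O)c1ccc(S(C)(=O)=O)c([N+](=O)[O-])c1` differs from compound 3 by fluoro in place of hydrogen on an aromatic carbon. Compound 1 carries the same 3-fluorobenzyl group together with a further methyl group elsewhere in the molecule, and it also sits at the limit. The measured steps thus offer no sign of a change in this assay in either direction; the expectation is none beyond the scatter. The expected step that the limit leaves unreadable from compound 3 to compound 4 is one of no readable size. Compound 4 is accordingly estimated at 100000 nM, within a range from 30000 nM to 300000 nM, most likely reported only as a limit again.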

Compound 4, half-maximal inhibitory concentration: > 60000 nM
Compound 4: a limit, no number; the forecaster's own chance of this, stated with the estimate: 85%; the middle value does not contradict the limit.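

The steps to compound 4 from compound 1, compound 2 and compound 3 cannot be read, because each of the four values is a limit and not a number: the limit of > 60000 nM in this assay, at which 4 of the 4 values shown sit.

The compounds shown leave open how strongly any of the four inhibits the receptor, and whether adding or moving the fluoro group, or removing the methyl group, changes that strength at all.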